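Alkyl variation at the aromatic carbon of compound 3

The source may hold more compounds than are shown below. What is called first, only, known or untested is meant among the compounds shown, and "the series" means these compounds.

Measured so far in an assay on membranes from brain for displacement of a labelled ligand from Neuronal acetylcholine receptor; alpha4/beta2 (Rattus norvegicus); on this read-out lower numbers stand for stronger inhibition and higher numbers for weaker inhibition:
- compound 1 `CN1CCC[C@H]1COc1cncc(C(F)(F)F)c1` gives 1.83 nM
- compound 2 `CN1CCC[C@H]1COc1cncc(Cl)c1` gives 0.6 nM
- compound 3 `Cc1cncc(OC[C@@H]2CCCN2C)c1` gives 0.48 nM

Compound 3 holds the lowest number of the three, but the gap to compound 2 is within the scatter, so the two cannot be ordered; only compound 1 stands apart, with a 3.8-fold lower number from compound 1 to compound 3 (0.58 log units; beyond the scatter) and a 3.1-fold lower number from compound 1 to compound 2 (0.48 log units; beyond the scatter). The step of a 1.3-fold lower number from compound 2 to compound 3 (0.10 log units; within the scatter) is within the scatter.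

Compound 4 `CCc1cncc(OC[C@@H]2CCCN2C)c1` differs from compound 3 by methyl in place of hydrogen on a saturated chain carbon bound to an aromatic carbon. Among the compounds with values here, no measured step covers this change; the nearest, between compound 2 and compound 3, shows no movement beyond the scatter, and the only substantive step concerns trifluoromethyl. On this basis the expected step of a 1.7-fold higher number from compound 3 to compound 4 (0.22 log units; within the scatter) is small, with no clear direction. Compound 4 is estimated at 0.8 nM, in the range 0.3 nM to 2.5 nM.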

Compound 4, inhibition constant: 0.32 nM
Beside the measured number, compound 4's estimate is 2.5-fold (0.40 log units) above it, within the range that was stated.
By their numbers in this assay, from the lowest: compounds 4, 3 and 2 (each within the scatter of the next); then compound 1.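

In this assay, methyl to ethyl on this aromatic carbon stays within the scatter (a 1.5-fold lower number from compound 3 to compound 4 (0.18 log units; within the scatter)), and ethyl in place of chloro does too (a 1.9-fold lower number from compound 2 to compound 4 (0.27 log units; within the scatter)), so ethyl cannot be ordered against methyl or chloro here. Ethyl, like methyl and chloro, stands apart from trifluoromethyl (a 5.7-fold lower number from compound 1 to compound 4 (0.76 log units; beyond the scatter)). No supporting data bear on why these numbers fall as they do. Open: whether a longer chain such as propyl, a branched one such as isopropyl, or an amine or carboxylic acid at this carbon would keep the number.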